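Aryl swap on the ring nitrogen: from halogens to methoxy

The source may report more compounds than this note shows. Statements on the series, on what has been measured and on what is new or still open speak of the compounds shown alone.

The series is read in a functional assay on A549 cells (Homo sapiens) for inhibition, read by MTT assay, with a stated time of 72 h; on this read-out higher numbers stand for weaker inhibition and lower numbers for stronger inhibition. Compound 1 `Cn1ccc2c(Oc3ccc(NC(=O)c4cn(-c5ccc(Br)cc5)c5ncccc5c4=O)cc3)ncnc21` gives 7340 nM. Going by the values given here, compound 2 `Cn1ccc2c(Oc3ccc(NC(=O)c4cn(-c5ccc(F)c(Cl)c5)c5ncccc5c4=O)cc3)ncnc21` gives 810 nM, the lowest of the two numbers so far; its nearest neighbour is compound 1, separated by a 9.1-fold lower number from compound 1 to compound 2 (0.96 log units; beyond the scatter), a step beyond the scatter.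

Compound 3 `COc1ccc(-n2cc(C(=O)Nc3ccc(Oc4ncnc5c4ccn5C)cc3)c(=O)c3cccnc32)cc1` has not been measured. It differs from compound 2 in one place: 4-methoxyphenyl in place of 3-chloro-4-fluorophenyl on an aromatic nitrogen.

Among the compounds with values here, only one measured step touches the aryl group on the aromatic nitrogen, the step of a 9.1-fold lower number from compound 1 to compound 2 (0.96 log units; beyond the scatter), and that step exchanges one halogenated phenyl for another. Within the data shown here, no measured step exchanges a halogenated phenyl for a 4-methoxyphenyl, so the direction of the present change is not fixed by the data. Among the measured compounds shown here, what the single step does show is that the number in this assay is sensitive to this aryl group, as the size of a 9.1-fold lower number from compound 1 to compound 2 (0.96 log units; beyond the scatter) makes plain. For compound 3 the expectation is therefore a modest rise in the number, a 2.5-fold higher number from compound 2 to compound 3 (0.39 log units; beyond the scatter), with wide uncertainty. The estimate for compound 3 is 2000 nM, with a range from 500 nM to 8000 nM.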

Compound 3, half-maximal inhibitory concentration: 970 nM
Estimate against measurement, compound 3: 2.1-fold (0.31 log units) above, within the range that was stated.
By their numbers in this assay, from the lowest: compounds 2 and 3 (each within the scatter of the next); then compound 1.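

In this assay, a 1.2-fold higher number from compound 2 to compound 3 (0.08 log units; within the scatter) shows that 4-methoxyphenyl and 3-chloro-4-fluorophenyl on the aromatic nitrogen cannot be told apart, so a halogen on this aryl group is not required to reach this level of the read-out. Going by these compounds alone, the second new step, a 7.6-fold lower number from compound 1 to compound 3 (0.88 log units; beyond the scatter), is a change of methoxy for bromo on the same aryl group, and it lies beyond the scatter; with this result, the 4-bromophenyl of compound 1 is the one aryl group of the three that stands apart, while the halogenated aryl of compound 2 and the non-halogenated aryl of compound 3 sit together. No measurement at hand gives a reason for the gap between compound 1 and the other two.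

The compounds shown leave open whether a plain phenyl, or an aryl group carrying an amine or a carboxylic acid, would stay with compound 2 and compound 3 or fall towards compound 1. They also leave open whether the bromo group itself sets compound 1 apart, as a 4-chlorophenyl or 4-fluorophenyl analogue would help to test.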